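This account rests on a few compounds, and the source may have more. Where it says the series, first, only, none or still open, it means among the compounds named here.

Compound 1, `Cc1ccc2nc(Cn3c(=O)n(C4CC4)c4ccncc43)c(CCCCO)n2c1`: in an ADME assay on HEp-2 cells (Homo sapiens) for cytotoxicity, read by CCK-8 assay, with a stated time of 6 days (on this read-out lower numbers stand for higher toxicity in this test and higher numbers for lower toxicity in this test), compound 1 gives > 100000 nM, which is a limit of the assay rather than a number.
Compound 2, `O=c1n(Cc2nc3ccc(Cl)cn3c2CCCCO)c2cnccc2n1C1CC1`: in this assay compound 2 gives > 100000 nM, again a limit.
Compound 3, `Cc1ccn2c(CCCCO)c(Cn3c(=O)n(C4CC4)c4ccncc43)nc2c1`: in this assay compound 3 gives > 100000 nM, also a limit.

Compound 3 therefore stands exactly where the other two measured compounds stand, at the limit of > 100000 nM in this assay, at which 3 of the 3 values shown sit. Going by the values given here, the only measured step between neighbours, a step that the two limits leave unreadable from compound 1 to compound 2, has a size that cannot be read; both of its values are limits. That step, a swap of one small group for another on an aromatic carbon of the shared core, is the closest guide to the change now in question.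

Compound 4, `O=c1n(Cc2nc3cc(C(F)(F)F)ccn3c2CCCCO)c2cnccc2n1C1CC1`, has not yet been measured. Its difference from compound 3 is trifluoromethyl in place of methyl on an aromatic carbon, meta to a fused ring, opposite the ring nitrogen, para to a fused ring. Among the compounds with values here, with every measured value sitting at the limit and the one comparable step unreadable, no step beyond the scatter is expected in this assay, and the expected step of a number no higher from compound 3 to compound 4 (the limit leaves the size open) is essentially none. Compound 4 is expected to give about 100000 nM, in the range 30000 nM to 300000 nM, most likely reported again as a limit.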

Compound 4, half-maximal cytotoxic concentration: > 100000 nM
Compound 4: no number, only a limit; the forecaster's own chance of this, stated with the estimate: 85%; the middle value lies on the limit itself.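

Compound 3 and compound 4 both stand at a limit rather than a number, so the step between them cannot be read, any more than the earlier one from compound 1 to compound 2. The compounds shown leave open whether any swap on the shared core changes toxicity in this assay, because all of them rest at one point: the limit of > 100000 nM in this assay, at which 4 of the 4 values shown sit.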